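A few compounds are considered here, and "the series" means these few. Any claim that something is new, unique, unknown or untested is made for them only; others in the source may bear on it.

Series notes. Compound 1 `Nc1nn(C(=O)Nc2ccc(Cc3ccccc3)cc2)c2ccccc12` gives 16800 nM in a functional assay on NCI-H23 cells (Homo sapiens) for antiproliferative activity, read by sulforhodamine B assay, with a stated time of 48 h; on this read-out higher numbers stand for weaker inhibition of growth and lower numbers for stronger inhibition of growth. Compound 2 `Nc1nn(C(=O)Nc2ccc(Cc3ccccc3)cc2)c2ccc(Cl)cc12` gives 5340 nM; the step of a 3.1-fold lower number from compound 1 to compound 2 (0.50 log units; beyond the scatter) leaves compound 2 with the lower of the two numbers. Compound 3 `Nc1ccc2c(c1)c(N)nn2C(=O)Nc1ccc(Cc2ccccc2)cc1` differs from compound 2 by amino in place of chloro on an aromatic carbon. Among the measured compounds shown here, the only measured step at that position, a 3.1-fold lower number from compound 1 to compound 2 (0.50 log units; beyond the scatter), concerns a chloro entering against hydrogen, not an amino against chloro, so it bears only indirectly. A modest rise back toward compound 1 is expected, a 2.2-fold higher number from compound 2 to compound 3 (0.35 log units; beyond the scatter), with wide uncertainty. Compound 3 is estimated at 12000 nM, range 4000 nM to 36000 nM.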

Compound 3, concentration for 50% growth inhibition: 16900 nM
Compound 3: the middle estimate sits 1.4-fold (0.15 log units) below what was measured; measured number inside the range.
By their numbers in this assay, from the lowest: compound 2; then compounds 1 and 3 (each within the scatter of the next).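

Amino does not keep what chloro gave at this aromatic carbon: the change reads a 3.2-fold higher number from compound 2 to compound 3 (0.50 log units; beyond the scatter), a step beyond the scatter. Set against hydrogen, amino gives a 1.0-fold higher number from compound 1 to compound 3 (0.00 log units; within the scatter), so among the three groups only chloro stands apart, and the mere presence of a group here does not lower the number. Nothing measured on hand accounts for the difference between chloro and amino.

Open, going by these compounds, is whether the lower number extends to fluoro, bromo or methyl at this carbon. Also open, on these data alone, is whether an acetamide or a dimethylamino group would read like amino.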